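Triazole-linked triterpenoid oximes and enones: cytotoxicity notes

The compounds below may be only part of what the source reports. "The series", "measured", "known", "first", "only" and "open" are said of these compounds alone.

Measured compounds:
compound 1 `COc1cc(OC)c(-n2cc(CO/N=C3\CC[C@]4(C)[C@@H](CC/C=C(\C)CC/C=C(\C)CCC=C(C)C)[C@](C)(O)CC[C@H]4C3(C)C)nn2)c(OC)c1`, 12800 nM in a functional assay on HeLa cells (Homo sapiens) for cytotoxicity, read by MTT assay, with a stated time of 48 h; a higher number here means a weaker inhibitor, a lower number a stronger inhibitor
compound 2 `CC(C)=CCC/C(C)=C/CC/C(C)=C/CC[C@@H]1[C@@]2(C)CC/C(=N\OCc3cn(-c4ccncc4)nn3)C(C)(C)[C@@H]2CC[C@@]1(C)O`, 18800 nM in this assay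
compound 3 `COc1cc(OC)c(-n2cc(COc3ccc(/C=C4\C[C@]5(C)[C@@H](CC/C=C(\C)CC/C=C(\C)CCC=C(C)C)[C@](C)(O)CC[C@H]5C(C)(C)C4=O)cc3)nn2)c(OC)c1`, 17500 nM in this assay

Compound 1 and compound 2 share one core; compound 3 and the unmeasured compound 4 `CC(C)=CCC/C(C)=C/CC/C(C)=C/CC[C@@H]1[C@@]2(C)C/C(=C\c3ccc(OCc4cn(-c5ccncc5)nn4)cc3)C(=O)C(C)(C)[C@@H]2CC[C@@]1(C)O` share another. The difference between the two cores is not broken down here. Compound 3 sits second highest of the three numbers, within the scatter of both compound 2 and compound 1.

One change recurs twice across the set. From compound 1 to compound 2 it is pyridin-4-yl in place of 2,4,6-trimethoxyphenyl on an aromatic nitrogen, and it gave a 1.5-fold higher number from compound 1 to compound 2 (0.17 log units; within the scatter). From compound 3 to compound 4 the change is pyridin-4-yl in place of 2,4,6-trimethoxyphenyl on an aromatic nitrogen, and the place line is the same word for word, so this is the same change on the other core. The only direct evidence is the single step from compound 1 to compound 2, which stayed within the scatter, so the change is not shown to move the number either way on the first core, and nothing is known about whether the second core behaves alike.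

On that basis compound 4 is expected to give 23000 nM in this assay, with a range from 11000 nM to 48000 nM. The expected step is a 1.3-fold higher number from compound 3 to compound 4 (0.12 log units; within the scatter), chosen to match the earlier step because of a 1.5-fold higher number from compound 1 to compound 2 (0.17 log units; within the scatter) and because compound 3 stands at 17500 nM.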

Compound 4, half-maximal inhibitory concentration: 77600 nM
Compound 4: middle estimate off by 3.4-fold (0.53 log units), on the low side; the whole stated range lies below it.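

In this assay, pyridin-4-yl in place of 2,4,6-trimethoxyphenyl on an aromatic nitrogen of the five-membered aromatic ring with 3 nitrogen gives a 4.4-fold higher number from compound 3 to compound 4 (0.65 log units; beyond the scatter), so on the core of compound 3 the change weakens the compound by more than the usual scatter. For the compounds shown here, the size of the step does not carry over from one core to the other: the same change on two cores in this assay, a 1.5-fold higher number (0.17 log units; within the scatter) from compound 1 to compound 2 and a 4.4-fold higher number (0.65 log units; beyond the scatter) from compound 3 to compound 4, 3.0-fold (0.48 log units) apart, beyond the scatter of two such steps This shows that, for these two pairs, a reading on the core of compound 1 would not have given the size of the step on the core of compound 3, but with only one pair on each core it sets no rule for the series, does not establish a shared direction, and does not show which feature of the two cores goes with the gap.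

The compounds shown leave open whether a plain phenyl or a single methoxy on the phenyl ring would stand closer to 2,4,6-trimethoxyphenyl or to pyridin-4-yl on each core. They also leave open whether an amine or a carboxylic acid on that aromatic ring, or a longer chain linking the five-membered ring to the core, would keep the same gap between the two cores.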